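The source may hold more compounds than are shown below. What is called first, only, known or untested is meant among the compounds shown, and "the series" means these compounds.

Compound 1 `OC[C@H]1O[C@@H](n2cnc3c(OCc4ccccc4)ncnc32)[C@H](O)[C@@H]1O` gives 2090 nM in an assay on isolated protein for binding affinity to Equilibrative nucleoside transporter 1 (Homo sapiens); on this read-out lower numbers stand for stronger inhibition and higher numbers for weaker inhibition. Compound 2 `CC(=O)c1cc(Cl)ccc1Sc1nc(N)nc2c1ncn2[C@@H]1O[C@H](CO)[C@@H](O)[C@H]1O` gives 14500 nM. Compound 3 `OC[C@H]1O[C@@H](n2cnc3c(CSc4ccccc4Cl)ncnc32)[C@H](O)[C@@H]1O` gives 1780 nM.

Among these three, compound 3 carries the lowest number. Its nearest neighbour is compound 1, and the step of a 1.2-fold lower number from compound 1 to compound 3 (0.07 log units; within the scatter) lies within the scatter, so the two cannot be ordered. Compound 2 stands furthest away: compound 2 gives 14500 nM, whereas compound 3 gives 1780 nM, a gap beyond the scatter.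

Compound 4 `CC(C)(C)c1ccc(SCc2ncnc3c2ncn3[C@@H]2O[C@H](CO)[C@@H](O)[C@H]2O)cc1` is the next member. It differs from compound 3 in one place: 4-(tert-butyl)phenyl in place of 2-chlorophenyl on a sulfur. Within the data shown here, no measured step alters the aryl group on the sulfur; the only single-point step available, from compound 1 to compound 3, changes the substituent on an aromatic carbon of the core and stays within the scatter, so it offers no direction for the present change. With nothing in the data pointing either way, compound 4 is expected to stay close to compound 3, with a 1.0-fold higher number from compound 3 to compound 4 (0.00 log units; within the scatter) estimated as a step of no size beyond the scatter. Compound 4 is therefore estimated at 1800 nM in this assay, in a range from 700 nM to 4500 nM.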

Compound 4, half-maximal inhibitory concentration: 331000 nM
Compound 4: the middle estimate sits 180-fold (2.26 log units) below what was measured; measured number outside the range, above it.
By their numbers in this assay, from the lowest: compounds 3 and 1 (each within the scatter of the next); then compound 2; then compound 4.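

In this assay, the aryl group on a sulfur whose other neighbour is a saturated chain carbon proves to be a sensitive place: exchanging 2-chlorophenyl for 4-(tert-butyl)phenyl gives a 190-fold higher number from compound 3 to compound 4 (2.27 log units; beyond the scatter). Among these compounds, the only earlier step between compounds differing in one place, a 1.2-fold lower number from compound 1 to compound 3 (0.07 log units; within the scatter), stayed within the scatter, so the earlier compounds gave no sign that a single change could shift the number so far. The two aryl groups share the same ring and the same counts of hydrogen-bond donors and acceptors, and nothing available explains the size of this step.

The step removes the chlorine, introduces the tert-butyl group and moves the substituent on the ring all at once, so the compounds shown leave open which of these accounts for the rise. A plain phenyl, a 4-chlorophenyl or a 2-(tert-butyl)phenyl on the same sulfur would separate these possibilities, and a 4-methylphenyl or a phenyl ring bearing a carboxylic acid would show how the number responds to other groups at this place.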